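This account rests on a few compounds, and the source may have more. Where it says the series, first, only, none or still open, it means among the compounds named here.

Series notes. Within the data shown here, compound 1 `C=C(C)[C@@H]1CC=C(Cn2cc(COc3cccc(C4NC(=O)NC(C)=C4C(=O)OCC)c3)nn2)CC1` is the first anchor. In a functional assay on HT-29 cells (Homo sapiens) for inhibition, read by sulforhodamine B assay, with a stated time of 48 h (a lower number here means a stronger inhibitor of growth, a higher number a weaker inhibitor of growth), compound 1 gives 73400 nM. Compound 2 `C=C(C)[C@@H]1CC=C(Cn2cc(COc3cc(C4NC(=O)NC(C)=C4C(=O)OCC)ccc3OC)nn2)CC1` differs from compound 1 by methoxy in place of hydrogen on an aromatic carbon. For compound 2 this assay reports only a limit, > 100000 nM. The measured step is an at least 1.3-fold higher number from compound 1 to compound 2 (0.13 log units; that floor lies within the scatter), and that it ends at a limit is shown by the limit of > 100000 nM in this assay, at which 1 of the 3 values shown sits.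

Compound 3 `C=C(C)[C@@H]1CC=C(Cn2cc(COc3ccc(C4NC(=O)NC(C)=C4C(C)=O)cc3)nn2)CC1` carries another core; the difference between the core of compound 1 and the core of compound 3 is not broken down here. In this assay compound 3 gives 62600 nM. Set against compound 1, the two numbers lie within the scatter of each other, so no order is drawn between them.

Compound 4 `C=C(C)[C@@H]1CC=C(Cn2cc(COc3ccc(C4NC(=O)NC(C)=C4C(C)=O)cc3OC)nn2)CC1` is not yet measured. Its difference from compound 3 is methoxy in place of hydrogen on an aromatic carbon. This is the same kind of change as that from compound 1 to compound 2, though the surroundings differ: in compound 2 the entering group sits ortho to a large group and para to a large group, in compound 4 ortho to a large group and meta to a large group. Because an at least 1.3-fold higher number from compound 1 to compound 2 (0.13 log units; that floor lies within the scatter) was seen for the same kind of change, the step expected here is a 1.5-fold higher number from compound 3 to compound 4 (0.18 log units; within the scatter). For compound 4 in this assay the estimate is 95000 nM. For compound 4 the expected range runs from 50000 nM to 200000 nM. For compound 4 a result given only as a limit is considered quite possible.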

Compound 4, concentration for total growth inhibition: 95000 nM
The estimate for compound 4 equals the measured number at the digits printed, within the range that was stated.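

In this assay, methoxy in place of hydrogen on an aromatic carbon gives a 1.5-fold higher number from compound 3 to compound 4 (0.18 log units; within the scatter), so on the core of compound 3 the effect of this change cannot be told apart from the scatter of repeated measurements. Set beside the same change on the core of compound 1, the two steps compare as follows: the same change on two cores in this assay, an at least 1.3-fold higher number (0.13 log units; that floor lies within the scatter) from compound 1 to compound 2 and a 1.5-fold higher number (0.18 log units; within the scatter) from compound 3 to compound 4; the limit leaves it open whether they differ. The series therefore does not show that the change carries from one core to the other with the same size, nor that its size differs, as the result for compound 2 is a limit and not a number: the limit of > 100000 nM in this assay, at which 1 of the 4 values shown sits.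

Open, on these data alone, is whether another group at this place on the aromatic ring, such as a hydroxyl, an amine, a carboxylic acid or a longer alkoxy chain, would give a step beyond the scatter on either core. Also open, as far as these compounds go, is how much the place of the entering group counts apart from the core, as the two pairs differ in both and each core is represented by a single pair.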